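A few compounds are considered here, and "the series" means these few. Any claim that something is new, unique, unknown or untested is made for them only; others in the source may bear on it.

Values in an ADME assay on the whole organism (Mus musculus, strain BALB/c) for metabolic stability, read by LC-MS, at a dose of 3 mg/kg by the intravenous route (a higher number here means that the compound lasts longer, a lower number that the compound disappears faster), so far:
Compound 1 `CCn1nc(C)cc1C(=O)NCCCCn1c(NC(=O)c2cc(C)nn2CC)nc2cc(C(N)=O)ccc21` gives 0.59 h
Compound 2 `CCn1nc(C)cc1C(=O)Nc1nc2cc(C(N)=O)cc(OC)c2n1C/C=C/Cn1c(NC(=O)c2cc(C)nn2CC)nc2cc(C(N)=O)cc(OCCCNC(=O)OC(C)(C)C)c21` gives 10.5 h

Compound 2 stands highest of the two, and its gap to compound 1 lies beyond the usual scatter. The two differ in more than one place, so this gap does not isolate any single change.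

Compound 3 `CCn1nc(C)cc1C(=O)NCCCOc1cc(C(N)=O)cc2nc(NC(=O)c3cc(C)nn3CC)n(C/C=C/Cn3c(NC(=O)c4cc(C)nn4CC)nc4cc(C(N)=O)cc(OC)c43)c12` has 1-ethyl-3-methyl-1H-pyrazol-5-yl in place of tert-butoxy on a carbonyl carbon of compound 2 (1-ethyl-3-methyl-1H-pyrazol-5-yl in place of tert-butoxy on a carbonyl carbon). Among the compounds with values here, no measured step covers this exchange. Within the data shown here, the expectation therefore rests on compound 2, with 10.5 h as its only close measured neighbour. A small downward move in this assay is expected, with a 1.5-fold lower number from compound 2 to compound 3 (0.18 log units; within the scatter) estimated to stay within the scatter. For compound 3 the estimated half-life is 7 h (expected range 2.5 h to 18 h).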

Compound 3, half-life: 1.75 h
Estimate against measurement, compound 3: 4.0-fold (0.60 log units) above, outside the stated range (below it).
By their numbers in this assay, from the lowest: compound 1; then compound 3; then compound 2.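

Within the data shown here, at the carbonyl carbon whose other neighbour is the amide-type nitrogen, 1-ethyl-3-methyl-1H-pyrazol-5-yl in place of tert-butoxy gives the first single-place step: in this assay it is a 6.0-fold lower number from compound 2 to compound 3 (0.78 log units; beyond the scatter) and so the half-life depends on what this carbonyl carbon carries. Among these compounds, this rests on a single pair and covers only this one exchange. Nothing available explains the size of this step.

Still open, on these data alone, is whether the step follows the five-membered aromatic ring itself or the departure of tert-butoxy. A small group such as methyl or a phenyl ring on this carbonyl carbon, or a free amine in place of the whole acyl group, would help separate these two readings.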